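A few compounds are considered here, and "the series" means these few. Any claim that something is new, unique, unknown or untested is made for them only; others in the source may bear on it.

Compound 1 `CCCC/N=C(\NC#N)Nc1cccnc1`: 20 mg/kg
Compound 2 `CC(C)(C)C/N=C(/NC#N)Nc1cccnc1`: 2.5 mg/kg
Compound 3 `CCCCC(CC)C/N=C(\NC#N)Nc1cccnc1`: > 50 mg/kg, a limit of the assay

In a functional assay on the whole organism (blood, strain Wistar-Okamoto) with Rattus norvegicus as the target, with a stated time of 5 days (on this read-out higher numbers stand for an effect only at larger amounts of compound and lower numbers for an effect already at smaller amounts), compound 1 gives the higher of the two numbers shown; compound 2 sits clearly lower in this assay. Compound 3 reaches only (the limit of > 50 mg/kg in this assay, at which 1 of the 3 values shown sits). The change to compound 4 `N#CN/C(=N\C1CCCCC1)Nc1cccnc1` is cyclohexyl in place of butyl on a double-bonded nitrogen. Within the data shown here, the one measured step that enlarges the butyl, an at least 2.5-fold higher number from compound 1 to compound 3 (0.39 log units; beyond the scatter), moved the number upward; the lower number of compound 2 shows that a compact branched group can go the other way. Cyclohexyl is compact yet larger than butyl, and no step of the same kind has been measured. Compound 4 is estimated at 12 mg/kg, with a range from 3 mg/kg to 50 mg/kg. The expected step is a 1.7-fold lower number from compound 1 to compound 4 (0.22 log units; within the scatter).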

Compound 4, minimum effective dose: 20 mg/kg
Compound 4: the middle estimate sits 1.7-fold (0.22 log units) below what was measured, and the stated range covers the measured number.
By their numbers in this assay, from the lowest: compound 2; then compounds 1 and 4 (each within the scatter of the next). At a limit, above all of these: compound 3.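

In this assay, cyclohexyl in place of butyl on a double-bonded nitrogen gives no change at the digits printed from compound 1 to compound 4 (within the scatter). Among these compounds, a six-membered non-aromatic ring of carbon only thus fits at this place with the number held, something the open-chain groups of the earlier compounds could not show. Compound 3 remains the only compound at a limit of the assay: the limit of > 50 mg/kg in this assay, at which 1 of the 4 values shown sits.

Open, from the compounds shown here alone, is whether a smaller ring such as cyclopentyl would read the same here. Also open, going by these compounds, is what an amine or a carboxylic acid on the cyclohexyl ring would do to the number.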